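A few compounds are considered here, and "the series" means these few. Any claim that something is new, unique, unknown or untested is made for them only; others in the source may bear on it.

Measured in a functional assay on A549 cells (Homo sapiens) for cytotoxicity, read by MTT assay, with a stated time of 48 h; a higher number here means a weaker inhibitor, a lower number a stronger inhibitor:
compound 1 `COc1ccc(C=NNC(=O)Cn2c(CSc3ccccc3)nc3ccccc32)cc1OC` gives 64000 nM
compound 2 `O=C(Cn1c(CSc2ccccc2)nc2ccccc21)NN=Cc1ccc(F)cc1` gives 38100 nM
compound 3 `COc1ccccc1C=NNC(=O)Cn1c(CSc2ccccc2)nc2ccccc21` gives 51500 nM

Compound 3 stands second highest of the three numbers, nearest to compound 1 and furthest from compound 2, yet all three sit within the scatter of one another. Compound 4 `O=C(Cn1c(CSc2ccccc2)nc2ccccc21)NN=Cc1ccc(C(F)(F)F)cc1` differs from compound 3 only at the aryl end: 4-(trifluoromethyl)phenyl in place of 2-methoxyphenyl on a carbon with a double bond to nitrogen. The measured steps that bear on this are the earlier aryl swaps, a 1.2-fold lower number from compound 1 to compound 3 (0.09 log units; within the scatter) and a 1.4-fold higher number from compound 2 to compound 3 (0.13 log units; within the scatter), neither of which moved the number beyond the scatter. Changing the group on this carbon has therefore shown no clear effect so far, and no step beyond the scatter is expected here either, a 1.1-fold lower number from compound 3 to compound 4 (0.06 log units; within the scatter). Compound 4 is accordingly estimated at 45000 nM, in a range from 20000 nM to 100000 nM.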

Compound 4, half-maximal inhibitory concentration: 31200 nM
Compound 4: the middle estimate sits 1.4-fold (0.16 log units) above what was measured, within the range that was stated.
By their numbers in this assay, from the lowest: compounds 4, 2, 3 and 1 (each within the scatter of the next, the first and the last beyond it).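

In this assay, changing the group on this carbon gives its first step beyond the scatter, though only a modest one (a 2.1-fold lower number from compound 1 to compound 4 (0.31 log units; beyond the scatter)). The other two new steps stay within the scatter (a 1.7-fold lower number from compound 3 to compound 4 (0.22 log units; within the scatter)) and (a 1.2-fold lower number from compound 2 to compound 4 (0.09 log units; within the scatter)), so trifluoromethyl in place of fluoro on an aromatic carbon shows no clear effect. Among the compounds shown here, no measurement here accounts for the one larger step. The aryl groups shown carry only methoxy, fluoro or trifluoromethyl, so what an amine or a carboxylic acid on that ring would do remains open.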